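Triazolylmethyl thioether in the diaminonitrile series

The source may hold more compounds than are shown below. What is called first, only, known or untested is meant among the compounds shown, and "the series" means these compounds.

Notes on a small set of thioether analogues sharing one core. Compound 1 `CCOc1ccc(-c2c(C#N)c(N)nc(SCc3ccn[nH]3)c2C#N)cc1` carries a pyrazolylmethyl sulfanyl arm; compound 2 `N#Cc1c(N)nc(SCc2cccc(C(N)=O)c2)c(C#N)c1-c1ccc(OCC2CC2)cc1` a 3-carbamoylbenzyl sulfanyl arm; compound 3 `CC(C)COc1ccc(-c2c(C#N)c(N)nc(SCC(N)=O)c2C#N)cc1` a carbamoylmethyl sulfanyl arm together with a different alkoxy group. In an assay on CHO cells for displacement of a labelled ligand from adenosine receptor A1 (Homo sapiens), read by scintillation counting, with a stated time of 90 min (on this read-out lower numbers stand for stronger inhibition and higher numbers for weaker inhibition), compound 1 gives 21 nM, compound 2 gives 83 nM and compound 3 gives 603 nM. Compound 2 therefore stands second highest of the three numbers: its value sits well above that of compound 1 and well below that of compound 3, both separations lying beyond the usual scatter.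

Compound 4 `N#Cc1c(N)nc(SCc2ncn[nH]2)c(C#N)c1-c1ccc(OCC2CC2)cc1` keeps the cyclopropylmethoxy group of compound 2 and changes only the thioether arm: 1H-1,2,4-triazol-5-yl in place of 3-carbamoylphenyl on a saturated chain carbon bound to a sulfur. Among the compounds with values here, no pair of measured compounds shows exactly this exchange, so its size cannot be read from a recorded step. Within the data shown here, the only guide is that the azolylmethyl arm of compound 1, with 21 nM, gives the lowest number in the set, whereas the carbamoyl-bearing arms of compound 2 and compound 3 give the higher numbers.

On that basis the step from compound 2 to compound 4 is expected to lower the number, by a 2.8-fold lower number from compound 2 to compound 4 (0.44 log units; beyond the scatter), beyond the scatter but not dramatically. Compound 4 is estimated at 30 nM in this assay, with a range from 10 nM to 100 nM.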

Compound 4, inhibition constant: 338 nM
Compound 4: the middle estimate sits 11-fold (1.05 log units) below what was measured; the measured number lies above the stated range.
By their numbers in this assay, from the lowest: compound 1; then compound 2; then compounds 4 and 3 (each within the scatter of the next).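

In this assay, 1H-1,2,4-triazol-5-yl in place of 3-carbamoylphenyl on a saturated chain carbon bound to a sulfur gives a 4.1-fold higher number from compound 2 to compound 4 (0.61 log units; beyond the scatter), so on the cyclopropylmethoxy background the 3-carbamoylbenzyl arm is the better of the two at this position. The step goes against the earlier pattern of a low number for an azolylmethyl arm and a higher number for a carbamoyl-bearing arm: that pattern rested on compound 1 alone, which carries a different alkoxy group, and an azolylmethyl arm alone does not ensure a low number here. The compounds shown offer no measurement that explains the direction or size of this step.

From the compounds shown here alone, it remains open whether the better number of compound 2 depends on the carbamoyl group or on the phenyl ring, a question that a plain benzyl arm or a 3-carboxybenzyl arm on the same background would address. Going by these compounds, it also remains open how far the alkoxy group and the azole ring each contribute, which a pyrazolylmethyl arm paired with the cyclopropylmethoxy group would help to separate.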